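Substituent on the double-bonded nitrogen: three measured, one pending

The source may hold more compounds than are shown below. What is called first, only, known or untested is meant among the compounds shown, and "the series" means these compounds.

Compound 1 `CCCC/N=C(\S)OC[C@H]1OC(n2cnc3c(NC4CCOC4)ncnc32)[C@H](O)[C@@H]1O` gives 157 nM in an assay on DDT1 cells (Cricetulus griseus) for binding affinity to adenosine receptor A1 (Homo sapiens), read by radioligand binding; a higher number here means a weaker inhibitor, a lower number a stronger inhibitor.
Compound 2 `O[C@@H]1[C@@H](CO/C(S)=N/C2CCCCC2)OC(n2cnc3c(NC4CCOC4)ncnc32)[C@@H]1O` gives 253 nM in this assay.
Compound 3 `O[C@@H]1[C@@H](CO/C(S)=N/Cc2ccccc2)OC(n2cnc3c(NC4CCOC4)ncnc32)[C@@H]1O` gives 12 nM in this assay.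

Compound 3 holds the lowest number of the three: a 13-fold lower number from compound 1 to compound 3 (1.12 log units; beyond the scatter), and a 21-fold lower number from compound 2 to compound 3 (1.32 log units; beyond the scatter), both beyond the scatter. Between compound 1 and compound 2 the change is small, a 1.6-fold higher number from compound 1 to compound 2 (0.21 log units; within the scatter).

Compound 4 `C=CC/N=C(\S)OC[C@H]1OC(n2cnc3c(NC4CCOC4)ncnc32)[C@H](O)[C@@H]1O` differs from compound 3 by vinyl in place of phenyl on a saturated chain carbon bound to a double-bonded nitrogen. The two steps that bear on this are the ones that removed the phenyl, from compound 1 and compound 2 to compound 3; both were large. Replacing the phenyl by a vinyl moves compound 4 back toward the chain-bearing analogues, so a step upward in this assay is expected, of the order of a 9.2-fold higher number from compound 3 to compound 4 (0.96 log units; beyond the scatter). Compound 4 is estimated at 110 nM, with a range from 35 nM to 350 nM.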

Compound 4, inhibition constant: 35 nM
Compound 4: the middle estimate sits 3.1-fold (0.50 log units) above what was measured, within the range that was stated.
By their numbers in this assay, from the lowest: compound 3; then compound 4; then compounds 1 and 2 (each within the scatter of the next).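

In this assay an aromatic ring is not required for a lower number than butyl or cyclohexyl gives on the double-bonded nitrogen: allyl shows a 4.5-fold lower number from compound 1 to compound 4 (0.65 log units; beyond the scatter) and a 7.2-fold lower number from compound 2 to compound 4 (0.86 log units; beyond the scatter) and still gives up ground to benzyl, with a 2.9-fold higher number from compound 3 to compound 4 (0.46 log units; beyond the scatter) as the remaining gap. Among these four compounds, the position therefore does not divide simply into benzyl and everything else. No measurement here explains why allyl falls where it does.

Allyl differs from butyl in both chain length and the double bond, and the compounds shown do not separate the two. A saturated propyl group on the same nitrogen would address that, and a phenethyl group would test how far the phenyl can sit from that nitrogen.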